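The compounds below may be only part of what the source reports. "The series", "measured", "known", "first", "only" and "open" are said of these compounds alone.

Measured compounds:
- compound 1, `NC(=O)c1ccc(-c2ccc(F)c(C(=O)Nc3c[nH]nc3C(=O)Nc3ccc(F)cc3)c2F)cn1` — in a functional assay on A2058 cells (Homo sapiens) for antiproliferative activity, read by luminescence and CellTiter-Glo, with a stated time of 96 h (on this read-out lower numbers stand for stronger inhibition and higher numbers for weaker inhibition), compound 1 gives 295 nM
- compound 2, `NS(=O)(=O)c1ccc(Nc2nc(-c3cccc(-c4ccccc4)c3)c3nc[nH]c3n2)cc1` — in this assay compound 2 gives only a limit, > 100000 nM
- compound 3, `COC(=O)c1cccc(-c2ccc(F)c(C(=O)Nc3c[nH]nc3C(=O)Nc3ccc(F)cc3)c2F)c1` — in this assay the entry for compound 3 reads "not determined" (no result reported)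

Compound 3 therefore stands nowhere on the numbers shown: it has no single value of its own, and of the three entries one is a limit rather than a number (the limit of > 100000 nM in this assay, at which 1 of the 3 values shown sits). Only compound 1, with 295 nM, offers a measured point close in structure to the pair under discussion.

The step from compound 3 to compound 4, `NC(=O)c1cccc(-c2ccc(F)c(C(=O)Nc3c[nH]nc3C(=O)Nc3ccc(F)cc3)c2F)c1`, is amino in place of methoxy on a carbonyl carbon. Within the data shown here, with no measured pair of this kind, the size of the step in this assay cannot be read from the data; a change of this kind is expected to be modest, possibly a small gain, but nothing beyond the usual scatter can be asserted.

Compound 4 shares its core with compound 1, and compound 1 gives 295 nM, a value that anchors the expectation. Compound 4 is expected to give about 400 nM, within a range from 100 nM to 2000 nM.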

Compound 4, half-maximal inhibitory concentration: 1990 nM
For compound 4 the middle estimate is 5.0-fold (0.70 log units) below the measured one; the measured number falls inside the stated range.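

Among these compounds, with the shared core held fixed, 3-carbamoylphenyl in place of 6-carbamoylpyridin-3-yl on an aromatic carbon gives a 6.7-fold higher number from compound 1 to compound 4 (0.83 log units; beyond the scatter) in this assay, the first step at this position that can be read, and it lies beyond the usual scatter. The two carbamoyl-bearing groups are therefore not interchangeable on this core in this assay. The step from compound 3 to compound 4 cannot be read, as compound 3 has no reported result, and nothing shown accounts for the difference between compound 1 and compound 4.

Going by these compounds, what the carbamoyl group itself contributes on either aromatic group remains open. So does the outcome with a carboxylic acid or a nitrile in its place.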